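The compounds below may be only part of what the source reports. "The series", "measured", "known", "first", "only" and "open" are said of these compounds alone.

Measured so far in an ADME assay on Raji cells (Homo sapiens) for cytotoxicity, read by luminescence, with a stated time of 72 h; on this read-out higher numbers stand for an effect only at larger amounts of compound and lower numbers for an effect already at smaller amounts:
- compound 1 `CCOC(=O)c1c(-c2cc(F)cc(OC)c2)[nH]c2cc(OC)ccc2c1=O`: > 21500 nM
- compound 2 `CCOC(=O)c1c(-c2cccc(C)c2)[nH]c2cc(OC)ccc2c1=O`: > 21500 nM
- compound 3 `CCOC(=O)c1c(-c2cccc(OC)c2)[nH]c2cc(OC)ccc2c1=O`: > 21500 nM

Compound 1 sits at the limit of > 21500 nM in this assay, at which 3 of the 3 values shown sit. Each of these entries is a limit and not a number, so the true position of compound 1 cannot be read, and no order among the three can be given.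

Compound 4 `CCOC(=O)c1c(-c2cc(F)cc(OC)c2)[nH]c2cc(OC)c(Cl)cc2c1=O` keeps the core of compound 1 and adds one change, chloro in place of hydrogen on an aromatic carbon.

The measured steps offer little guidance. There is a step that the two limits leave unreadable from compound 1 to compound 2, then a step that the two limits leave unreadable from compound 1 to compound 3, and finally a step that the two limits leave unreadable from compound 2 to compound 3. Within the data shown here, none has a readable size, and none alters the carbon that takes the chloro, so no measured step speaks directly to this change.

The expectation therefore rests on compound 1 and its limit of > 21500 nM. In this assay, the expected step is a number no higher from compound 1 to compound 4 (the limit leaves the size open), and the data support no direction for it. Compound 4 is estimated at 21500 nM, with an expected range from 6000 nM to 40000 nM. It may well be reported only as a limit again.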

Compound 4, half-maximal effective concentration: > 21500 nM
Compound 4: only a limit was reported; the forecaster's own chance of this, stated with the estimate: 75%; the middle value lies on the limit itself.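

Compound 4 is again reported only as a limit, so no step from compound 1 to compound 4 can be read, and both stand at the same entry: the limit of > 21500 nM in this assay, at which 4 of the 4 values shown sit.

The compounds shown leave open where any of the four truly lies in this assay, and whether chloro in place of hydrogen on an aromatic carbon shifts the read-out at all.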